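The source may report more compounds than this note shows. Statements on the series, on what has been measured and on what is new or still open speak of the compounds shown alone.

Working notes on the series. Compound 1 `CN1[C@@H]2c3[nH]c4ccccc4c3C[C@H]1[C@H](C#N)N1[C@@H](CN3C(=O)c4ccccc4C3=O)c3[nH]c4ccccc4c3C[C@@H]21` gives 80 nM in a functional assay on A2780 cells (Homo sapiens) for cytotoxicity, read by MTT assay, with a stated time of 72 h; on this read-out lower numbers stand for stronger inhibition and higher numbers for weaker inhibition. Among the compounds with values here, compound 2 `CN1[C@@H]2c3[nH]c4ccccc4c3C[C@H]1[C@H](C#N)N1[C@@H](CNC(=O)c3ccc(F)cc3)c3[nH]c4ccccc4c3C[C@@H]21` gives 250 nM in the same assay and thus stands highest of the two numbers so far, the step being a 3.1-fold higher number from compound 1 to compound 2 (0.49 log units; beyond the scatter). Compound 3 `CN1[C@@H]2c3[nH]c4ccccc4c3C[C@H]1[C@H](C#N)N1[C@@H](CNC(=O)c3ccc4ccccc4n3)c3[nH]c4ccccc4c3C[C@@H]21` is yet to be measured. It differs from compound 2 by quinolin-2-yl in place of 4-fluorophenyl on a carbonyl carbon, that is, (4-fluorophenyl)carbonyl to (quinolin-2-yl)carbonyl on the amide-type nitrogen. Within the data shown here, no measured step exchanges one aryl group for another on this carbonyl carbon: the single step from compound 1 to compound 2 alters the amide itself and so bears on the present change only indirectly, suggesting that the substituent on this chain is tolerated with modest swings. The expectation for compound 3 is therefore a step of no change at the digits printed from compound 2 to compound 3 (within the scatter), within the scatter. Compound 3 is estimated at 250 nM, with a range of 100 nM to 630 nM.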

Compound 3, half-maximal inhibitory concentration: 60 nM
Compound 3: middle estimate off by 4.2-fold (0.62 log units), on the high side, and the stated range ends above it.
By their numbers in this assay, from the lowest: compounds 3 and 1 (each within the scatter of the next); then compound 2.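

In this assay the aryl group on this carbonyl carbon proves to be no silent place: quinolin-2-yl in place of 4-fluorophenyl gives a 4.2-fold lower number from compound 2 to compound 3 (0.62 log units; beyond the scatter) and so an exchange of one aryl group for another, with the amide kept, is enough to move the number beyond the scatter. The entering group differs from the leaving one at once in its second six-membered aromatic ring, its ring nitrogen, and its hydrogen-bond acceptor, and the loss of fluorine comes with them, so this single step cannot assign the shift to any one of these. Nothing measured on the origin of this shift is at hand.

The compounds shown leave open whether the added ring or the ring nitrogen carries the shift. Naphthalen-2-yl and pyridin-2-yl on the same carbonyl carbon would separate the two.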